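A few compounds are considered here, and "the series" means these few. Any claim that something is new, unique, unknown or untested is made for them only; others in the source may bear on it.

Measured so far:
Compound 1, `C1=CC[C@]23CCC[C@@]2(C1)CNC3`: in an ADME assay on MDCK cells (Canis lupus familiaris) for cytotoxicity, read by microscopy (a lower number here means that less compound is tolerated, a higher number that more compound is tolerated), compound 1 gives > 100000 nM, which is a limit of the assay.
Compound 2, `CC1CC23CC(C)CC2(C1)CN(C(=N)N)C3`: in this assay compound 2 gives > 100000 nM, also a limit of the assay.

Compound 2 therefore stands at the limit of > 100000 nM in this assay, at which 2 of the 2 values shown sit. Compound 3, `CC1CC23CNCC2(C1)CC(C)C3`, differs from compound 2 in one place: a hydrogen atom in place of a group of 3 heavy atoms (1 carbon, 2 nitrogen; no ring), on an amine nitrogen in a ring. Compound 1 also carries a hydrogen on that amine nitrogen, and it gave > 100000 nM. No step beyond the scatter is expected in this assay, and the expected step is a number no higher from compound 2 to compound 3 (the limit leaves the size open). Compound 3 is expected at 100000 nM, between 50000 nM and 200000 nM.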

Compound 3, minimum cytotoxic concentration: > 100000 nM
Compound 3: a limit, no number (the forecaster's own chance of this, stated with the estimate: 90%); the middle value lies on the limit itself.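

Within the data shown here, compound 2 and compound 3 both give only a limit of the assay, so no step between them can be read. In this assay the compounds shown leave open what concentration any of them fails to tolerate, and whether swapping the group on the amine nitrogen in a ring matters.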